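A few compounds are considered here, and "the series" means these few. Any claim that something is new, unique, unknown or untested is made for them only; others in the source may bear on it.

Measured in a functional assay on HT-1080 cells (Homo sapiens) for cytotoxicity, read by MTT assay, with a stated time of 72 h; a lower number here means a stronger inhibitor, a higher number a weaker inhibitor:
- compound 1 `COc1cccc(/C=C2\CCC/C(=C\c3ccccc3Cl)C2=O)c1OC`: 11700 nM
- compound 2 `COc1ccc(/C=C2\CCC/C(=C\c3cccc(OC)c3OC)C2=O)cc1`: 16300 nM

Compound 2 gives 16300 nM and shares the top of this short series with compound 1, since the two values lie within the scatter of each other. Neither can be ranked ahead of the other on these numbers.

The next compound is compound 3 `COc1cccc(/C=C2\CCC/C(=C\c3ccc(Cl)cc3Cl)C2=O)c1OC`. It differs from compound 2 as follows: 2,4-dichlorophenyl in place of 4-methoxyphenyl on a double-bonded chain carbon bound to a double-bonded ring carbon. The exchange sits on a double-bonded chain carbon bound to a double-bonded ring carbon, and the rest of the structure is unchanged.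

Among the measured compounds shown here, only one measured step bears on this, a 1.4-fold higher number from compound 1 to compound 2 (0.14 log units; within the scatter). It concerns the same place and also has 4-methoxyphenyl on one side and a chlorinated phenyl on the other. That step stays within the scatter, so no large change is expected in this assay. For the measured compounds named here, no measured compound carries 2,4-dichlorophenyl, so this evidence is thin and the range is kept wide.

The expected change is a 1.5-fold lower number from compound 2 to compound 3 (0.17 log units; within the scatter), with no clear shift beyond the scatter anticipated. For compound 3 the estimate is 11000 nM, with an expected range of 5000 nM to 24000 nM.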

Compound 3, half-maximal inhibitory concentration: > 20000 nM
Compound 3 gave a limit, no number (the forecaster's own chance of this, stated with the estimate: 3%); middle value at least 1.8-fold (0.25 log units) from the limit.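

In this assay compound 3 gives > 20000 nM as a limit of the assay, not a number. With 2,4-dichlorophenyl in place of 4-methoxyphenyl on a double-bonded chain carbon bound to a double-bonded ring carbon, the reading is an at least 1.2-fold higher number from compound 2 to compound 3 (0.08 log units; that floor lies within the scatter) and, with chloro in place of hydrogen on an aromatic carbon, it is an at least 1.7-fold higher number from compound 1 to compound 3 (0.23 log units; that floor lies within the scatter); this position therefore now holds a group that takes the read-out out of the measured range, which the two earlier compounds did not show. Among the compounds shown here, neither floor establishes a change beyond the scatter, and no other compound here shares the limit: the limit of > 20000 nM in this assay, at which 1 of the 3 values shown sits.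

On these data alone, the true distance of compound 3 from compound 1 and compound 2 stays open, and with it whether the added chloro makes any real difference in this assay. Also open, as far as these compounds go, is how a group of another kind at this place, such as an amine or a carboxylic acid carried on the phenyl ring, would read against the chlorinated and methoxylated phenyl groups on the shared core.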